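The compounds below may be only part of what the source reports. "The series", "measured", "known", "first", "only" and "open" are said of these compounds alone.

This piece follows a single change made to compound 1 `Cc1ccccc1CNc1nn(-c2ccc(F)cc2F)cc1CNCCN1CCN(C)CC1` and what it might do to how much of the compound cells tolerate. In an ADME assay on Huh-7 cells (Homo sapiens) for cytotoxicity (a higher number here means that more compound is tolerated, a lower number that less compound is tolerated), compound 1 gives > 20000 nM, and that figure is a limit of the assay rather than a measured number. Two further compounds share the same core but differ from compound 1 in several places. In this assay compound 2 `CN1CCN(CCNCc2cn(-c3ccc([N+](=O)[O-])cc3)nc2-c2ccc(OC(F)(F)F)cc2)CC1` gives 4400 nM. In this assay compound 3 `CN1CCN(CCCNCc2cn(-c3ccc(C(F)(F)F)cc3)nc2-c2ccc(C(F)(F)F)cc2)CC1` gives 2000 nM. Compound 1 therefore stands at the limit of > 20000 nM in this assay, at which 1 of the 3 values shown sits, while compound 2 and compound 3 sit at measured numbers beneath it. Compound 4 `CN1CCN(CCNCc2cn(-c3ccc(F)cc3F)nc2-c2ccccc2)CC1` differs from compound 1 in one place: phenyl in place of (2-methylbenzyl)amino on an aromatic carbon. Within the data shown here, no pair of measured compounds differs in exactly this way, so the size of the step can only be estimated. Because compound 2 gives 4400 nM and compound 3 gives 2000 nM, both carrying an aromatic ring in place of an amino-linked group, the expectation is that compound 4 is tolerated less well than compound 1. The expected step is an at least 2.5-fold lower number from compound 1 to compound 4 (0.39 log units; beyond the scatter), downward and beyond the scatter. For compound 4 the estimated value in this assay is 8000 nM, with a range from 3000 nM to 20000 nM.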

Compound 4, half-maximal cytotoxic concentration: > 20000 nM
Compound 4 was reported as a limit (the forecaster's own chance of this, stated with the estimate: 30%); middle value at least 2.5-fold (0.39 log units) away from the limit.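

In this assay compound 4 gives > 20000 nM, which is a limit of the assay. Among these compounds, compound 1 stands at the same limit, so no step between compound 1 and compound 4 can be read: the limit of > 20000 nM in this assay, at which 2 of the 4 values shown sit. The compounds shown leave open whether phenyl in place of (2-methylbenzyl)amino changes how much compound cells tolerate.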